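Methyl for chloro on the aryl amine of compound 3

The source may hold more compounds than are shown below. What is called first, only, known or untested is meant among the compounds shown, and "the series" means these compounds.

Three analogues of one core have been run in a functional assay on the whole organism (strain Wistar) with Rattus norvegicus as the target, with stated times of 30 min and 4 h, at a dose of 5 mg/kg by the intraperitoneal route; on this read-out lower numbers stand for a weaker effect and higher numbers for a stronger effect at the one dose given. Compound 1 `O=S(=O)(Nc1ccncc1Nc1cccc(Br)c1)C(F)(F)F` gives 27.1% in this assay, and compound 2 `O=S(=O)(Nc1ccncc1Nc1ccc(F)c(Cl)c1)C(F)(F)F` gives 14.7%. Compound 3 `O=S(=O)(Nc1ccncc1Nc1cccc(Cl)c1)C(F)(F)F` is recorded only as "not active" (no number reported) in this assay, with no number attached, so it stands apart from compound 1 and compound 2 as the member without a measured percentage, and it cannot be placed on the scale relative to either of them.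

Compound 4 `Cc1cccc(Nc2cnccc2NS(=O)(=O)C(F)(F)F)c1` remains to be measured in this assay. It differs from compound 3 in one place: methyl in place of chloro on an aromatic carbon. Cut one bond further out, the change reads 3-chlorophenyl to 3-methylphenyl, with no change in ring count, donors, acceptors or charge.

For the measured compounds named here, no step between measured compounds covers this exchange, so nothing tells how large a shift to expect. Given that compound 3 showed no recorded activity, the step to compound 4 is expected to be small, at most a modest rise that may not exceed the usual scatter. Compound 4 is estimated at 12% in this assay, within a range of 0% to 30%.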

Compound 4, a percentage reported as activity, at one dose (the size of the read-out at that dose, not a potency): 17.1%
For compound 4 the middle estimate is 5.1 percentage points below the measured one; measured number inside the range.
By their numbers in this assay, from the lowest: compounds 2, 4 and 1 (each within the scatter of the next, the first and the last beyond it).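

In this assay compound 4 gives 17.1% with a methyl group on the ring, so a recorded percentage at this position does not depend on a halogen there, and the exchange of bromo for methyl gives a number 10 percentage points lower from compound 1 to compound 4 (within the scatter) and does not separate the two groups on this read-out. The step from chloro to methyl cannot be read: compound 3 carries only the label "not active" with no number, so the contrast between chloro and methyl is a label set against a percentage and has no size. Nothing measured here gives a reason for how these groups behave at this position.

On these data alone, whether the label on compound 3 marks a real gap from its bromo and methyl counterparts remains open. Also open, as far as these compounds go, is how this position takes a group built from other atoms, such as a methoxy, an amine or a carboxylic acid, or a longer chain such as ethyl in place of methyl, and whether any of these moves the percentage beyond the scatter.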